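Cyclopentyl for fluorocyclobutyl: metabolic stability expected to hold

This account rests on a few compounds, and the source may have more. Where it says the series, first, only, none or still open, it means among the compounds named here.

Compound 1 `N#Cc1ccnc(Oc2nn(C3CCC3)c3ncnc(N)c23)c1`: 2.35 h
Compound 2 `Nc1ncnc2c1c(Oc1cc(C(F)(F)F)ccn1)nn2[C@H]1CC[C@@H](N)CC1`: > 2.41 h
Compound 3 `Nc1ncnc2c1c(Oc1cc(C(F)(F)F)ccn1)nn2[C@H]1C[C@H](F)C1`: 2.03 h

In an ADME assay on microsomes from liver (Homo sapiens) for metabolic stability, read by LC-MS, using NADPH, with a stated time of 10 min, tested at 10 uM (a higher number here means that the compound lasts longer, a lower number that the compound disappears faster), compound 1 gives 2.35 h and compound 3 gives 2.03 h. For compound 2 the reading is a limit of the assay, > 2.41 h (the limit of > 2.41 h in this assay, at which 1 of the 3 values shown sits), not a number. Among the two numbers compound 3 stands lowest, with compound 1 nearest and within the scatter of it. Among the compounds with values here, the single measured step at this position, an at least 1.1-fold lower number from compound 2 to compound 3 (0.07 log units; that floor lies within the scatter), also stays within the scatter. Compound 4 `Nc1ncnc2c1c(Oc1cc(C(F)(F)F)ccn1)nn2C1CCCC1` differs from compound 3 by cyclopentyl in place of 3-fluorocyclobutyl on an aromatic nitrogen. That step bears on the change only loosely, and its size gives no ground to expect a step beyond the scatter. Compound 4 is therefore expected to give about 1.8 h, estimated between 1 h and 2.4 h, an expected step of a 1.1-fold lower number from compound 3 to compound 4 (0.05 log units; within the scatter).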

Compound 4, half-life: 0.333 h
For compound 4 the middle estimate is 5.4-fold (0.73 log units) above the measured one; measured number below the stated range.
By their numbers in this assay, from the lowest: compound 4; then compounds 3 and 1 (each within the scatter of the next). At a limit, above all of these: compound 2.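

In this assay, within the data shown here, the group on the aromatic nitrogen turns out to matter for the first time, even between two rings equal in heavy atoms: cyclopentyl in place of 3-fluorocyclobutyl gives a 6.1-fold lower number from compound 3 to compound 4 (0.79 log units; beyond the scatter). Cyclopentyl in place of 4-aminocyclohexyl points the same way, with an at least 7.2-fold lower number from compound 2 to compound 4 (0.85 log units; beyond the scatter). Compound 2 stands at a limit of the assay, not at a number: the limit of > 2.41 h in this assay, at which 1 of the 4 values shown sits.

From the compounds shown here alone, whether the fluorine or the ring size carries the step stays open. A plain cyclobutyl group with the trifluoromethyl kept, or a 3-fluorocyclopentyl group, would bear on that.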